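A few compounds are considered here, and "the series" means these few. Any claim that something is new, unique, unknown or untested is made for them only; others in the source may bear on it.

Of the compounds shown here, three have been measured in a physicochemical assay for lipophilicity, read by HPLC, at pH 7.5; a higher number here means a more lipophilic compound, a lower number a more polar compound. Compound 1 `CC[C@@H](Nc1c(C#N)c(-c2ccc(-c3ncccc3C)cc2)nc2cnccc12)C(N)=O` gives 2, and compound 3 `CC[C@@H](Nc1c(C#N)c(-c2ccc(-c3ccncc3C)cc2)nc2cnccc12)C(N)=O` gives 2. Within the data shown here, the one step between measured compounds, no change at the digits printed from compound 1 to compound 3 (within the scatter), shows that swapping one methylpyridinyl group for another left the reading where it was. Compound 2 `CCCCC(Nc1c(C#N)c(-c2ccc(-c3ccccc3OCC)cc2)nc2cnccc12)C(N)=O` stands highest of the three with 3.6, a value beyond the scatter above both compound 1 and compound 3.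

Compound 4 `CCOc1ccccc1-c1ccc(-c2nc3cnccc3c(N[C@H](CC)C(=O)NS(C)(=O)=O)c2C#N)cc1` has not yet been measured. It differs from compound 2 in the group attached to the nitrogen on the aromatic ring: a group of 10 heavy atoms (5 carbon, 1 nitrogen, 3 oxygen, 1 sulfur; no ring) in place of a group of 8 heavy atoms (6 carbon, 1 nitrogen, 1 oxygen; no ring), on a nitrogen on an aromatic ring. Compound 2 keeps the primary amide and a longer carbon chain, whereas the entering group carries more oxygens, a sulfur and fewer carbons.

The measured step from compound 1 to compound 3 concerns a different part of the molecule and showed no change, so it does not bear directly on this change. Among the measured compounds shown here, no measured step touches the group on the nitrogen. Given the loss of carbons and the gain of oxygens and sulfur in the counted difference, the reading for compound 4 in this assay is expected to fall, by a number 2.30 log units lower from compound 2 to compound 4 (beyond the scatter). Compound 4 is therefore estimated at 1.3, within a range from 0.3 to 2.5.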

Compound 4, distribution coefficient: 2.2
Compound 4: the middle estimate sits 0.90 log units below what was measured; measured number inside the range.
By their numbers in this assay, from the lowest: compounds 1, 3 and 4 (each within the scatter of the next); then compound 2.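

The group on a nitrogen on an aromatic ring turns out to be a place where the reading can move: in this assay, exchanging the 1-carbamoylpentyl group for the group of 10 heavy atoms (5 carbon, 1 nitrogen, 3 oxygen, 1 sulfur; no ring) gives a number 1.40 log units lower from compound 2 to compound 4 (beyond the scatter). Among these compounds, the earlier step, at a different place in the molecule, gave no change at the digits printed from compound 1 to compound 3 (within the scatter), so this is the first measured sign that the reading in this assay responds to a change. No independent measurement among the data accounts for the size of this step.

The entering group differs from the 1-carbamoylpentyl group in its carbon count and in its oxygen and sulfur atoms together, so the compounds shown leave open how much of the step belongs to each of these differences. Also open, going by these compounds, is where the reading would fall if this group ended in a carboxylic acid or an amine instead, with the rest of compound 2 kept the same.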